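The compounds below may be only part of what the source reports. "The series", "measured", "known", "first", "only" and "open" are said of these compounds alone.

The study covers three compounds. Compound 1, with the structure `CC(=O)CC/C=C(\C)CCC1=C(C)CCCC1(C)C`, and compound 2, with the structure `C=C1CCCC(C)(C)C1CC[C@]1(C)CC[C@@H]([C@@H](C)C(=O)O)OO1`, have been measured; compound 3, with the structure `C=C1CCCC(C)(C)C1CC[C@@]1(C)CC[C@H]([C@@H](C)C(=O)O)OO1`, has not. The read-out is a functional assay on HCC 2998 cells (Homo sapiens) for inhibition; on this read-out higher numbers stand for weaker inhibition of growth and lower numbers for stronger inhibition of growth.

For compound 2 the result is a limit of the assay, not a number: in this assay compound 2 gives > 10000 nM. For compound 1 the result is likewise only a limit: in this assay compound 1 gives > 15000 nM. Going by the values given here, compound 2 therefore stands at a limit, and the one other value shown is a limit as well, so neither compound gives a number to compare against.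

Among the compounds with values here, compound 3 differs from compound 2 as follows: the two compounds have the same atoms and bonds; at least one stereo element is drawn with a configuration in one of them and without one in the other: 2 of 4 stereo elements differ; a stereocentre at a saturated ring carbon is drawn R in compound 2 and S in compound 3; a stereocentre at a saturated ring carbon is drawn S in compound 2 and R in compound 3 No step between measured compounds is available, so there is nothing that tells how much such a change moves the result in this assay. Since compound 2 sits at a limit, the expectation is that compound 3 will also show no growth inhibition within the measured range, giving no step beyond the scatter as a step that the limit leaves unreadable from compound 2 to compound 3. Compound 3 is therefore estimated at 15000 nM, within a range from 5000 nM to 50000 nM.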

Compound 3, concentration for 50% growth inhibition: 6780 nM
Compound 3: the middle estimate sits 2.2-fold (0.34 log units) above what was measured; measured number inside the range.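

In this assay, going by these compounds alone, compound 3 gives 6780 nM, the only number among the three compounds. The other two results are limits. The pair has the same atoms and bonds and differs only in the two saturated ring stereocentres, which are drawn with opposite configurations, and the result is an at least 1.4-fold lower number from compound 2 to compound 3 (0.16 log units; that floor lies within the scatter), so this floor alone does not establish a difference beyond the scatter. The true size of the step stays unknown because compound 2 gives only a limit: the limit of > 10000 nM in this assay, at which 1 of the 3 values shown sits.

The compounds shown leave open what the other two stereo elements contribute, since they are the same in this pair, and whether changing only one of the two ring stereocentres would move the result in this assay. They also do not tell how the result would respond if an ester or an amide took the place of the carboxylic acid on this scaffold, or if a longer chain were present.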